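Notes on a chloro to methyl exchange

This account rests on a few compounds, and the source may have more. Where it says the series, first, only, none or still open, it means among the compounds named here.

Measured in a functional assay on Jurkat cells (Homo sapiens) for antiproliferative activity, read by MTT assay, with a stated time of 72 h; on this read-out higher numbers stand for weaker inhibition and lower numbers for stronger inhibition:
- compound 1 `COc1cc(C(=O)c2sc3ccccc3c2-c2ccccc2)cc(OC)c1OC`: 1500 nM
- compound 2 `COc1cc(C(=O)c2sc3ccccc3c2Nc2ccc(Cl)cc2)cc(OC)c1OC`: 1900 nM

Compound 2, at 1900 nM, lies within the scatter of compound 1, so the two numbers cannot be ordered. The unmeasured compound 3 `COc1cc(C(=O)c2sc3ccccc3c2Nc2ccc(C)cc2)cc(OC)c1OC` differs from compound 2 by methyl in place of chloro on an aromatic carbon. This is methyl in place of chloro on an aromatic carbon, para to a large group, so (4-chlorophenyl)amino becomes (4-methylphenyl)amino.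

Among the measured compounds shown here, only one measured step bears on this: a 1.3-fold higher number from compound 1 to compound 2 (0.10 log units; within the scatter). For the measured compounds named here, it replaces a whole group at that place, and no measured pair compares chloro with methyl directly. No shift beyond the scatter is therefore expected in this assay, and no direction can be given.

The expected step is a 1.2-fold lower number from compound 2 to compound 3 (0.07 log units; within the scatter). The estimated value for compound 3 is 1600 nM, with an expected range of 650 nM to 3800 nM.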

Compound 3, half-maximal inhibitory concentration: 1700 nM
Estimate against measurement, compound 3: 1.1-fold (0.03 log units) below; measured number inside the range.
By their numbers in this assay, from the lowest: compounds 1, 3 and 2 (each within the scatter of the next).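

In this assay the chloro to methyl exchange can now be read directly, and a 1.1-fold lower number from compound 2 to compound 3 (0.05 log units; within the scatter) shows that chloro and methyl on this aromatic carbon, para to a large group, cannot be told apart. Replacing phenyl with (4-methylphenyl)amino gives a 1.1-fold higher number from compound 1 to compound 3 (0.05 log units; within the scatter) and so, like the (4-chlorophenyl)amino group of compound 2, leaves the number within the scatter of compound 1. No supporting measurement bears on this result.

Going by these compounds, whether another group at this place, such as a carboxylic acid, a primary amine or a longer alkyl chain, would move the number beyond the scatter remains open. Also open, on these data alone, is whether the chloro to methyl exchange would read the same way elsewhere on the shared core.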